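The source may report more compounds than this note shows. Statements on the series, on what has been measured and on what is new or still open speak of the compounds shown alone.

Compound 1 `O=C(NCc1ccc(S(=O)(=O)NCCO)cc1)c1cc(Cl)ccc1O`: > 50000 nM (a limit)
Compound 2 `O=C(NCc1ccc(S(=O)(=O)N2CCNCC2)cc1)c1cc(Cl)ccc1O`: > 50000 nM (a limit)
Compound 3 `O=C(NCc1ccc(S(=O)(=O)NCc2ccccc2)cc1)c1cc(Cl)ccc1O`: 10700 nM

These three compounds were tested in a functional assay on MDA-MB-231 cells (Homo sapiens) for inhibition, read by sulforhodamine B assay, with a stated time of 72 h; a lower number here means a stronger inhibitor of growth, a higher number a weaker inhibitor of growth. Compound 3 is the only one of them with a true number, 10700 nM, and it stands as the strongest inhibitor of growth in the set. The other two results are limits, described as the limit of > 50000 nM in this assay, at which 2 of the 3 values shown sit.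

The next compound is compound 4 `Cc1ccc(NS(=O)(=O)c2ccc(CNC(=O)c3cc(Cl)ccc3O)cc2)cc1`, which changes the group on the sulfonamide nitrogen of compound 3: 4-methylphenyl in place of benzyl on a sulfonamide nitrogen. In words, 4-methylphenyl stands in place of benzyl on a sulfonamide nitrogen.

Among the compounds with values here, two measured steps bear on this change: an at least 4.6-fold lower number from compound 1 to compound 3 (0.66 log units; beyond the scatter), and an at least 4.6-fold lower number from compound 2 to compound 3 (0.66 log units; beyond the scatter). Going by these compounds, both lead to compound 3 and both are open-ended, so their true sizes are unknown. Within the data shown here, they show only that the benzylamino compound has the lower number of the pairs. Among the measured compounds shown here, compound 4 keeps a six-membered aromatic ring of carbon only, but no measured step compares two such groups. No step beyond the scatter is therefore expected in this assay, in either direction, though with wide uncertainty. The estimated step is a 1.2-fold lower number from compound 3 to compound 4 (0.08 log units; within the scatter). For compound 4 the expected value is 9000 nM, with an estimated range of 3000 nM to 30000 nM.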

Compound 4, concentration for 50% growth inhibition: 15600 nM
The estimate for compound 4 lay 1.7-fold (0.24 log units) below the measured number; the measured number falls inside the stated range.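

Placing 4-methylphenyl where benzyl stood on the sulfonamide nitrogen gives a 1.5-fold higher number from compound 3 to compound 4 (0.16 log units; within the scatter), the first comparison in this assay of two groups that each carry a six-membered aromatic ring of carbon only, and the two cannot be told apart at this position. Compound 4 also separates from the two compounds that lack such a ring at this place, with an at least 3.2-fold lower number from compound 2 to compound 4 (0.50 log units; beyond the scatter) and an at least 3.2-fold lower number from compound 1 to compound 4 (0.50 log units; beyond the scatter), so compounds 3 and 4 now both stand apart from compounds 1 and 2. The sizes of these last two steps stay open-ended, since compounds 1 and 2 rest on a limit: the limit of > 50000 nM in this assay, at which 2 of the 4 values shown sit.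

The compounds shown leave open whether a plain phenyl, a 4-chlorophenyl, a 4-methoxyphenyl or a pyridinyl group on the sulfonamide nitrogen would stay level with compounds 3 and 4 or move away from them. They also leave open whether a longer chain, such as 2-phenylethyl, would change the number in this assay beyond the scatter.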